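Replacing the pyridyl ester with a chlorophenyl ester

This account rests on a few compounds, and the source may have more. Where it says the series, first, only, none or still open, it means among the compounds named here.

Compound 1, `C=CCc1ccc(OC(=O)c2ccccn2)c(OC)c1`, gives 0.86 in a physicochemical assay for lipophilicity; on this read-out lower numbers stand for lower lipophilicity and higher numbers for higher lipophilicity.
Compound 2, `C=CCc1ccc(OC(=O)c2ccccc2C)c(OC)c1`, gives 2.87.
Compound 3, `C=CCc1ccc(OC(=O)c2cccnc2)c(OC)c1`, gives 0.86.

Compound 3 stands level with compound 1 at the digits shown, and together the two are the lowest of the three numbers. Its nearest neighbour is compound 1: no change at the digits printed from compound 1 to compound 3 (within the scatter). Its furthest is compound 2: a number 2.01 log units lower from compound 2 to compound 3 (beyond the scatter).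

Compound 4, `C=CCc1ccc(OC(=O)c2cccc(Cl)c2)c(OC)c1`, is not yet measured. It carries 3-chlorophenyl in place of pyridin-3-yl on a carbonyl carbon.

Among the measured compounds shown here, two measured steps bear on this change, and both swap a pyridyl for a phenyl that bears one substituent on the same carbonyl carbon: a number 2.01 log units higher from compound 1 to compound 2 (beyond the scatter), and, read in the opposite direction, a number 2.01 log units lower from compound 2 to compound 3 (beyond the scatter). The third step, no change at the digits printed from compound 1 to compound 3 (within the scatter), shows that the two pyridyl groups sit at the same level, so the swap from pyridin-3-yl is expected to behave like the swap from pyridin-2-yl. For the measured compounds named here, no measured step exchanges a pyridyl for a chlorophenyl, so the size of a chlorine against a methyl is not fixed by these data. A large rise in this assay is therefore expected for compound 4, roughly a number 2.24 log units higher from compound 3 to compound 4 (beyond the scatter). The estimate for compound 4 is 3.1, with a range from 2.6 to 3.6.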

Compound 4, partition coefficient: 2.79
Beside the measured number, compound 4's estimate is 0.31 log units above it; measured number inside the range.
By their numbers in this assay, from the lowest: compounds 1 and 3 (each within the scatter of the next); then compounds 4 and 2 (each within the scatter of the next).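

In this assay, replacing pyridin-3-yl with 3-chlorophenyl on the carbonyl carbon gives a number 1.93 log units higher from compound 3 to compound 4 (beyond the scatter) and replacing pyridin-2-yl with it gives a number 1.93 log units higher from compound 1 to compound 4 (beyond the scatter) in the same way, so the large rise seen earlier with 2-methylphenyl is not confined to that one group and also appears with a phenyl ring that carries chlorine. The two substituted phenyl esters do not separate on this read-out, with a number 0.08 log units lower from compound 2 to compound 4 (within the scatter) as the step between them, so exchanging the methyl-bearing ring for the chlorine-bearing ring leaves the level where it was and the gap to the pyridyl esters is kept. The information available offers no explanation for the size of these steps or for the match between the two phenyl esters.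

The compounds shown leave open where an unsubstituted phenyl, or a phenyl carrying an amine or a carboxylic acid, would stand in this assay on the same carbonyl carbon. Since the groups in compound 2 and compound 4 differ in both the substituent and its place on the ring, the effects of these two differences also remain unseparated.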